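This account rests on a few compounds, and the source may have more. Where it says the series, first, only, none or still open, it means among the compounds named here.

Compound 3 `C=C1C(=O)O[C@@H](c2ccccc2)[C@H]1c1ccccc1` gives the lowest number of the three measured compounds in a functional assay on MIA PaCa-2 cells (Homo sapiens) for cytotoxicity, read by MTT assay, with a stated time of 72 h, tested at 1 uM (on this read-out lower numbers stand for a stronger effect and higher numbers for a weaker effect at the one concentration tested), namely 32%. In this assay compound 1 `C=C1C(=O)O[C@@H](c2ccccc2)[C@H]1C` gives 114% and compound 2 `C=C1C(=O)O[C@@H](c2ccc(OC)cc2)[C@H]1C` gives 109%. Compound 4 `C=C1C(=O)O[C@H](c2ccccc2)[C@H]1c1ccccc1` differs from compound 3 only in configuration: the two compounds have the same atoms and bonds and differ only in configuration as drawn: 1 of 2 stereo elements differ; a stereocentre at a saturated ring carbon is drawn R in compound 3 and S in compound 4. Within the data shown here, no measured step changes configuration alone, so none bears on it directly; the step of a number 82 percentage points lower from compound 1 to compound 3 (beyond the scatter) shows how large the change to phenyl on the saturated ring carbon was, while a number 5 percentage points lower from compound 1 to compound 2 (within the scatter) stays within the scatter. Among the measured compounds shown here, with no precedent for the configuration change, compound 4 is expected to give a somewhat higher number than its diastereomer, a step of a number 18 percentage points higher from compound 3 to compound 4 (beyond the scatter) in this assay. The estimate for compound 4 is 50%, between 25% and 95%.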

Compound 4, a percentage reported as activity, at one concentration (the size of the read-out at that concentration, not a potency): 30%
For compound 4 the middle estimate is 20 percentage points above the measured one, and the stated range covers the measured number.
By their numbers in this assay, from the lowest: compounds 4 and 3 (each within the scatter of the next); then compounds 2 and 1 (each within the scatter of the next).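

In this assay, the change of configuration at the saturated ring carbon gives a number 2 percentage points lower from compound 3 to compound 4 (within the scatter), so with phenyl on the saturated ring carbon the read-out at this one concentration does not separate the two drawn forms. The earlier compounds showed only what a change of group did; this step isolates configuration, and the comparison is clean on one point: the fact that compounds 3 and 4 differ only in the configuration as drawn

On these data alone, it remains open whether the same holds with methyl at that carbon, as in compound 1, or with an aminomethyl group or a longer alkyl chain there. A single concentration also leaves open whether compound 3 and compound 4 match across a full dose range.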